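This account rests on a few compounds, and the source may have more. Where it says the series, first, only, none or still open, it means among the compounds named here.

Compound 1 `COc1cccc(OS(=O)(=O)c2ccc(N3CCN(C)C3=O)cc2)c1` and compound 2 `CN1CCN(c2ccc(S(=O)(=O)Oc3cccc(F)c3)cc2)C1=O` share a core and differ in one place: fluoro in place of methoxy on an aromatic carbon. In a functional assay on M21 cells (Homo sapiens) for antiproliferative activity, read by sulforhodamine B assay, with a stated time of 48 h (on this read-out lower numbers stand for stronger inhibition and higher numbers for weaker inhibition), compound 1 gives 1600 nM, while compound 2 gives 5800 nM, so this change produced a 3.6-fold higher number from compound 1 to compound 2 (0.56 log units; beyond the scatter). Compound 3 `CCCN1CCN(c2ccc(S(=O)(=O)Oc3ccc(OC)cc3)cc2)C1=O` is built on a different core; how it differs from the core of compound 1 is not broken down here. In this assay compound 3 gives 23000 nM, the highest of the three numbers. Compound 4 `CCCN1CCN(c2ccc(S(=O)(=O)Oc3ccc(F)cc3)cc2)C1=O` has not yet been measured; it stands to compound 3 as compound 2 stands to compound 1: fluoro in place of methoxy on an aromatic carbon. The place is not quite identical, however: for compound 1 and compound 2 the group sits meta to a large group, whereas for compound 3 and compound 4 it sits para to a large group, so this is the same kind of change rather than the same change. Because the earlier swap gave a 3.6-fold higher number from compound 1 to compound 2 (0.56 log units; beyond the scatter), a step in the same direction is expected in this assay, namely a 2.2-fold higher number from compound 3 to compound 4 (0.34 log units; beyond the scatter), although the different place and the different core leave its size uncertain. Compound 4 is therefore estimated at 50000 nM, within a range from 15000 nM to 150000 nM.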

Compound 4, half-maximal inhibitory concentration: 14000 nM
Beside the measured number, compound 4's estimate is 3.6-fold (0.55 log units) above it; measured number below the stated range.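

In this assay, for the compounds shown here, putting fluoro in place of methoxy gives a 1.6-fold lower number from compound 3 to compound 4 (0.22 log units; within the scatter), so on this core the swap produces no step that stands clear of repeat-measurement noise. The change therefore does not carry over from one core to the other with a fixed size, and a step seen on one core was a poor guide to the other, as the two steps set side by side show: the same change on two cores in this assay, a 3.6-fold higher number (0.56 log units; beyond the scatter) from compound 1 to compound 2 and a 1.6-fold lower number (0.22 log units; within the scatter) from compound 3 to compound 4, 6.0-fold (0.77 log units) apart, beyond the scatter of two such steps What this does not show is the reason, since the two pairs differ both in their core and in where the group sits on the aromatic ring, and two pairs cannot separate those differences.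

The compounds shown leave open whether the swap would behave alike on both cores with the group held at one same place. They also leave open how a chloro group, an amine or a carboxylic acid in that place would compare with methoxy and fluoro.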